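From 4-methoxyphenyl to 3-fluorophenyl on the shared core

This account rests on a few compounds, and the source may have more. Where it says the series, first, only, none or still open, it means among the compounds named here.

Measured in a toxicity assay on THP-1 cells (Homo sapiens) for inhibition; on this read-out lower numbers stand for higher toxicity in this test and higher numbers for lower toxicity in this test:
Compound 1 `Cn1c(-c2ccc(Br)cc2)cnc1NC(=O)c1ccc(F)cc1`: 46000 nM
Compound 2 `Cn1c(-c2cccc([N+](=O)[O-])c2)cnc1NC(=O)c1ccc(F)cc1`: > 50000 nM, a limit of the assay
Compound 3 `COc1ccc(-c2cnc(NC(=O)c3ccc(F)cc3)n2C)cc1`: >= 50000 nM, a limit of the assay

Compound 3 stands at a limit of this assay, >= 50000 nM, and has no exact number. Compound 4 `Cn1c(-c2cccc(F)c2)cnc1NC(=O)c1ccc(F)cc1` carries 3-fluorophenyl in place of 4-methoxyphenyl on an aromatic carbon. Within the data shown here, only one measured step bears on this change, an at least 1.0-fold higher number from compound 1 to compound 3 (0.03 log units; that floor lies within the scatter), a methoxy in place of bromo on an aromatic carbon, and its floor lies within the scatter. On that evidence, the expected step is no larger than the scatter, a number no higher from compound 3 to compound 4 (the limit leaves the size open), and its direction is left open. For compound 4 the estimate is 50000 nM, with an expected range of 25000 nM to 100000 nM.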

Compound 4, half-maximal cytotoxic concentration: 58000 nM
For compound 4 the middle estimate is 1.2-fold (0.06 log units) below the measured one; measured number inside the range.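

In this assay, 3-fluorophenyl in place of 4-bromophenyl on this aromatic carbon gives a 1.3-fold higher number from compound 1 to compound 4 (0.10 log units; within the scatter), so compound 1 and compound 4 cannot be told apart. Among these compounds, compound 4 thus gives this position a second exact value, where the earlier compounds gave only one. On these data alone, the steps to compound 4 from compound 2 and from compound 3 cannot be read, and how far those two compounds lie from compound 4 stays open. As far as these compounds go, whether an amine or a carboxylic acid on the phenyl ring would keep the read-out in this range also stays open.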